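Amine variation on the side chain of the shared core

The compounds below may be only part of what the source reports. "The series", "measured", "known", "first", "only" and "open" are said of these compounds alone.

Among the measured compounds shown here, compound 2 `Nc1nc(-c2ccco2)nc2sc(CNC3CCCCC3)cc12` gives 2480 nM in an assay on CHO-K1 cells for antagonist activity at adenosine receptor A1 (Homo sapiens), read by a beta-galactosidase reporter, with stated times of 15 min and 6 h (a higher number here means a weaker inhibitor, a lower number a stronger inhibitor), and stands highest of the three numbers so far; compound 1 `CCN(CC)Cc1cc2c(N)nc(-c3ccco3)nc2s1` gives 2130 nM, within the scatter of compound 2, while compound 3 `Cc1ccc(-c2nc(N)c3cc(CN4CCCCC4)sc3n2)o1` gives 610 nM, a clearly lower number. For the measured compounds named here, the only step at the same place is a 1.2-fold higher number from compound 1 to compound 2 (0.07 log units; within the scatter), an amine swap that stayed within the scatter. Compound 4 `Nc1nc(-c2ccco2)nc2sc(CN3CCC(F)CC3)cc12` differs from compound 2 by 4-fluoropiperidin-1-yl in place of cyclohexylamino on a saturated chain carbon bound to an aromatic carbon. Compound 3 also carries a cyclic amine at this place, but it differs from compound 2 in the furan as well, so its lower number cannot be tied to the amine alone. Given that a 1.2-fold higher number from compound 1 to compound 2 (0.07 log units; within the scatter) stayed within the scatter, compound 4 is expected to show a step of a 1.4-fold lower number from compound 2 to compound 4 (0.14 log units; within the scatter) in this assay. Compound 4 is therefore estimated at 1800 nM, with a range from 700 nM to 4500 nM.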

Compound 4, inhibition constant: 740 nM
Estimate against measurement, compound 4: 2.4-fold (0.39 log units) above, within the range that was stated.
By their numbers in this assay, from the lowest: compounds 3 and 4 (each within the scatter of the next); then compounds 1 and 2 (each within the scatter of the next).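

In this assay, the amine on this saturated chain carbon now makes a difference beyond the scatter: a 3.4-fold lower number from compound 2 to compound 4 (0.53 log units; beyond the scatter), and a 2.9-fold lower number from compound 1 to compound 4 (0.46 log units; beyond the scatter), whereas the swap between the two earlier amines stayed within it. Nothing measured here explains this step.

Among the compounds shown here, whether the step belongs to the fluorine or to the ring nitrogen-linked piperidine stays open, as the one piperidin-1-yl compound without fluorine, compound 3, also differs in the furan. As far as these compounds go, how morpholin-4-yl or 4-hydroxypiperidin-1-yl would read at this place also remains open.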